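This account rests on a few compounds, and the source may have more. Where it says the series, first, only, none or still open, it means among the compounds named here.

Measured so far:
Compound 1, `O=C(Nc1cc(-c2ccccc2)nn1-c1ccccc1)c1ccc(C(F)(F)F)cc1`: 990 nM
Compound 2, `NC(=O)c1ccc(C(=O)Nc2cc(-c3ccccc3)nn2-c2ccccc2)cc1`: > 10000 nM

In an assay on HEK293 cells for displacement of a labelled ligand from metabotropic glutamate receptor 5 (Rattus norvegicus) (a lower number here means a stronger inhibitor, a higher number a weaker inhibitor), compound 1 gives 990 nM. For compound 2 the assay reports only a limit and not a number, > 10000 nM, which is the limit of > 10000 nM in this assay, at which 1 of the 2 values shown sits. Compound 2 thus stands at the weak end of what can be read here, and the step of an at least 10-fold higher number from compound 1 to compound 2 (1.00 log units; beyond the scatter) marks a clear loss on moving from trifluoromethyl to carbamoyl.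

Compound 3, `O=C(Nc1cc(-c2ccccc2)nn1-c1ccccc1)C1CCCCC1`, differs from compound 2 by cyclohexyl in place of 4-carbamoylphenyl on a carbonyl carbon. Among the measured compounds shown here, the single measured step that bears on this, an at least 10-fold higher number from compound 1 to compound 2 (1.00 log units; beyond the scatter), ran the other way: it brought in the carbamoylphenyl that compound 3 now takes out. A move back in the direction of compound 1 is therefore expected, though its exact size is uncertain since the reading for compound 2 is only a limit. The expected step is an at least 3.3-fold lower number from compound 2 to compound 3 (0.52 log units; beyond the scatter). Compound 3 is estimated at 3000 nM, with a range from 700 nM to 15000 nM.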

Compound 3, inhibition constant: 10100 nM
Beside the measured number, compound 3's estimate is 3.4-fold (0.53 log units) below it; the measured number falls inside the stated range.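

Until now only the group on the aromatic ring had changed, whereas compound 3 replaces that ring itself; in this assay, cyclohexyl in place of 4-(trifluoromethyl)phenyl on the carbonyl carbon gives a 10-fold higher number from compound 1 to compound 3 (1.01 log units; beyond the scatter) in this series. The loss at this place is therefore not tied to the carbamoyl group, since cyclohexyl, with 0 hydrogen-bond donors and 0 hydrogen-bond acceptors, also gives a weaker compound than compound 1. The step between compound 2 and compound 3 cannot be read, because compound 2 stands at a limit: the limit of > 10000 nM in this assay, at which 1 of the 3 values shown sits.

The compounds shown leave open how much of the value of compound 1 rests on the trifluoromethyl group and how much on the aromatic ring that carries it. A plain phenyl at this place would separate the two, and a chlorine atom or a methoxy group on the aromatic carbon would show how specific trifluoromethyl is.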